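Carbonyl substituent change from compound 1 to compound 3

The compounds below may be only part of what the source reports. "The series", "measured", "known", "first", "only" and "open" are said of these compounds alone.

Measured compounds:
- compound 1, `O=C(O)c1cccn1-c1ccc2c(c1)B(O)OC2`, in an ADME assay on L929 cells (Mus musculus) for cytotoxicity, read by resazurin assay, with a stated time of 72 h (a lower number here means a stronger inhibitor, a higher number a weaker inhibitor), gives > 10 ug/mL.
- compound 2, `Cc1ccccc1C(=O)c1ccn(-c2ccc3c(c2)B(O)OC3)c1`, in this assay gives > 10 ug/mL.

Both values recorded so far are limits of the assay rather than numbers. For compound 1 the value in this assay is a limit only. For compound 2 the value in this assay is likewise a limit only. Compound 1 therefore stands at the limit of > 10 ug/mL in this assay, at which 2 of the 2 values shown sit, and nothing in the shown data separates it from compound 2; no order between the two can be read from limits alone.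

The unmeasured compound 3, `CC(=O)c1cccn1-c1ccc2c(c1)B(O)OC2`, differs from compound 1 in one place: methyl in place of hydroxy on a carbonyl carbon, or read one bond further out, carboxy to acetyl. For the measured compounds named here, no step between measured compounds is available, so the size of this change in this assay has to be guessed. Since compound 1 sits at the limit, as the limit of > 10 ug/mL in this assay, at which 2 of the 2 values shown sit, records, the step is expected to be none beyond the scatter, a step that the limit leaves unreadable from compound 1 to compound 3. Compound 3 is accordingly expected to give about 20 ug/mL in this assay, in a range from 7 ug/mL to 60 ug/mL, most likely again reported as a limit.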

Compound 3, half-maximal inhibitory concentration: > 10 ug/mL
Compound 3 gave a limit, no number; the forecaster's own chance of this, stated with the estimate: 75%; the middle value does not contradict the limit.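

In this assay compound 1 and compound 3 are both recorded as limits and not as numbers, so the exchange of hydroxy for methyl on the carbonyl carbon gives no readable step between them. The compounds shown leave open whether carboxy to acetyl changes the read-out at all, and where any of these compounds would fall as a number.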